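Methyl on the Five-Membered Ring of a Fused Core

A few compounds are considered here, and "the series" means these few. Any claim that something is new, unique, unknown or untested is made for them only; others in the source may bear on it.

Compound 1: `COc1ccc(-n2ncc3c(NC(C4CC4)C4CC4)nc(C)nc32)c(C)c1`, 32 nM
Compound 2: `COc1ccc(-n2cnc3c(NC(C4CC4)C4CC4)nc(C)nc32)c(C)c1`, 47 nM

Of the compounds shown here, two have been measured so far in a functional assay on CHO cells for antagonist activity at corticotropin-releasing factor receptor 1 (Homo sapiens), read by cAMP accumulation; a higher number here means a weaker inhibitor, a lower number a stronger inhibitor. Compound 1 gives 32 nM, and compound 2 gives 47 nM. Compound 2 has the higher of the two numbers, but its gap to compound 1 is within the scatter, so no order between them can be read from this assay.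

Compound 3, `COc1ccc(-n2c(C)nc3c(NC(C4CC4)C4CC4)nc(C)nc32)c(C)c1`, is not yet measured. It differs from compound 2 in one place: methyl in place of hydrogen on an aromatic carbon. Among the compounds with values here, no measured pair shows the effect of such a change on this core, so nothing in the data points to a step in either direction. The expectation for compound 3 is therefore a number close to that of compound 2, with a wide band; the step from compound 2 to compound 3 is estimated as a 1.3-fold lower number from compound 2 to compound 3 (0.13 log units; within the scatter). In this assay compound 3 is expected to give 35 nM, most likely between 9 nM and 140 nM.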

Compound 3, inhibition constant: 14 nM
The estimate for compound 3 lay 2.5-fold (0.40 log units) above the measured number; low and high end bracket the measured number.
By their numbers in this assay, from the lowest: compound 3; then compounds 1 and 2 (each within the scatter of the next).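

The carbon between two ring nitrogen atoms proves responsive to substitution: in this assay, methyl in place of hydrogen gives a 3.4-fold lower number from compound 2 to compound 3 (0.53 log units; beyond the scatter) and this modest step lies beyond the scatter. Within the data shown here, it is the first step on this core that can be read, and it shows that this position, next to the ring atom that bears the 4-methoxy-2-methylphenyl group, accepts a methyl with a gain in inhibition. Nothing available explains the size or direction of this step.

The compounds shown hold only hydrogen and methyl at this carbon, so it remains open how an ethyl group, a trifluoromethyl group or an amine there would behave. Also open, on these data alone, is whether the same methyl change would carry over to the core of compound 1.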